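The compounds below may be only part of what the source reports. "The series", "measured", "known", "first", "only" and "open" are said of these compounds alone.

Three compounds of the shared core have been run in an assay on isolated protein for agonist activity at Bile acid receptor (Homo sapiens), read by AlphaScreen, with a stated time of 30 min; on this read-out higher numbers stand for an effect only at larger amounts of compound and lower numbers for an effect already at smaller amounts. Compound 1 `Cc1ccccc1-n1nc(C)c2c1NC(=O)[C@H](C)S[C@@H]2c1ccc(Oc2ccccc2)cc1` gives 3000 nM; 1400 nM (2 entries); the spread of these two entries is shown in the several entries of compound 1 in this assay, 3000 nM; 1400 nM (2 entries). Compound 2 `CCC1SC(c2ccc(Oc3ccccc3)cc2)c2c(C)nn(-c3ccccc3C)c2NC1=O` gives 3000 nM. Compound 3 `CCc1nn(-c2ccccc2C)c2c1[C@@H](c1ccc(Oc3ccccc3)cc1)S[C@@H](C)C(=O)N2` gives 2000 nM, the lowest of the two single numbers, though its gap to compound 2 lies within the scatter, so no order between them is claimed. Compound 4 `Cc1ccccc1-n1ncc2c1NC(=O)[C@H](C)S[C@@H]2c1ccc(Oc2ccccc2)cc1` is not yet measured; it differs from compound 3 by hydrogen in place of ethyl on an aromatic carbon. Going by the values given here, no measured pair isolates this change, and compound 1 and compound 3 alone give no size for it. For compound 4 in this assay a small loss is expected, a 1.5-fold higher number from compound 3 to compound 4 (0.18 log units; within the scatter), not clearly beyond the scatter. The estimate for compound 4 is 3000 nM, with a range from 1000 nM to 9000 nM.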

Compound 4, half-maximal effective concentration: > 150000 nM
Compound 4 was reported as a limit; the forecaster's own chance of this, stated with the estimate: 10%; middle value at least 50-fold (1.69 log units) away from the limit.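

In this assay hydrogen in place of ethyl on this aromatic carbon is a large loss (an at least 75-fold higher number from compound 3 to compound 4 (1.87 log units; beyond the scatter)). Compound 4 is reported only as a limit of the assay, not a number (> 150000 nM). Measurable values so far go with a carbon group at this place: methyl in compound 1 (3000 nM; 1400 nM (2 entries)) and ethyl in compound 3 (2000 nM).

From the compounds shown here alone, whether a longer chain, a cyclopropyl ring or an amine on this carbon would keep such values remains open. Nothing shown accounts for the loss.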